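Fluoro removal on the central ring of a triazole sulfone series

The source may report more compounds than this note shows. Statements on the series, on what has been measured and on what is new or still open speak of the compounds shown alone.

Measured compounds in an ADME assay on microsomes from liver (Homo sapiens) for metabolic stability; on this read-out lower numbers stand for slow clearance and higher numbers for fast clearance:
- compound 1, `COc1cc(-c2nnc(S(=O)(=O)C3CCC3)[nH]2)ccc1-c1cnc(OCC(C)C)c(Cl)c1`: 59 uL/min
- compound 2, `CC(C)COc1ncc(-c2cc(F)c(-c3nnc(S(=O)(=O)NC4CC4)[nH]3)cc2F)cc1Cl`: 125 uL/min
- compound 3, `CC(C)COc1ncc(-c2cc(F)c(-c3nnc(S(=O)(=O)C4CCC4)[nH]3)cc2F)cc1Cl`: 53 uL/min

Compound 3 gives the lowest of the three numbers in this assay. Its nearest neighbour is compound 1, whose value sits within the scatter of that of compound 3, so no order can be set between them. Within the data shown here, compound 2 stands furthest away: the step of a 2.4-fold lower number from compound 2 to compound 3 (0.37 log units; beyond the scatter) is beyond the scatter and is the only single-place step measured in the set, and it concerns the sulfonyl substituent, not the ring carrying the fluoro groups.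

Compound 4, `CC(C)COc1ncc(-c2ccc(-c3nnc(S(=O)(=O)C4CCC4)[nH]3)cc2F)cc1Cl`, differs from compound 3 in one place: hydrogen in place of fluoro on an aromatic carbon. Among the measured compounds shown here, no measured step bears directly on this change. Compound 1, which carries no fluoro on that ring but differs from compound 3 elsewhere as well, sits within the scatter of compound 3, which gives no sign of a large effect from that ring's substitution. The step of a 1.1-fold higher number from compound 3 to compound 4 (0.04 log units; within the scatter) is therefore expected to stay within the scatter. Compound 4 is estimated at 58 uL/min, in the range 28 uL/min to 115 uL/min.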

Compound 4, intrinsic clearance in a liver preparation (reported as CLH), per the amount of preparation that the assay uses: 93 uL/min
For compound 4 the middle estimate is 1.6-fold (0.21 log units) below the measured one; the measured number falls inside the stated range.
By their numbers in this assay, from the lowest: compounds 3, 1, 4 and 2 (each within the scatter of the next, the first and the last beyond it).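

In this assay this carbon, ortho to a large group and para to a fluoro group, now has a direct reading: a 1.8-fold higher number from compound 3 to compound 4 (0.24 log units; within the scatter) for hydrogen in place of fluoro, so the change cannot be told from the scatter. Fluoro in place of methoxy at another carbon of the same ring gives a 1.6-fold higher number from compound 1 to compound 4 (0.20 log units; within the scatter) and so also cannot be told from the scatter. No data on hand account for either step.

Still open, as far as these compounds go, is whether an amine or a nitrile at this carbon would give a reading beyond the scatter. Also open, from the compounds shown here alone, are whether hydrogen in place of both fluoro groups would do so, and whether hydrogen in place of fluoro reads the same with cyclopropylamino on the sulfonyl sulfur.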